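Ester in place of thioester on the shared core

A few compounds are considered here, and "the series" means these few. Any claim that something is new, unique, unknown or untested is made for them only; others in the source may bear on it.

Compound 1, `CC1=C(C(=O)CC(C)C)C(c2ccsc2)NC(=O)N1`: 14%
Compound 2, `CCSC(=O)C1=C(C)NC(=O)NC1c1ccsc1`: 2%
Compound 3, `CC1=C(C(=O)SC(C)C)C(c2ccsc2)NC(=O)N1`: 1%

Three compounds share one core and differ only in the group on the carbonyl carbon. In an assay on membranes from HeLa cells for displacement of a labelled ligand from adenosine receptor A3 (Homo sapiens), read by scintillation counting, with a stated time of 180 min, tested at 1 uM (a higher number here means more inhibition at the concentration tested (going by the name of the read-out), a lower number less inhibition), compound 1 gives 14%. Swapping its isobutyl for ethylsulfanyl or isopropylsulfanyl brings the number down: a number 12 percentage points lower from compound 1 to compound 2 (beyond the scatter) and a number 13 percentage points lower from compound 1 to compound 3 (beyond the scatter). Between the two sulfanyl compounds the change is small: a number 1 percentage points lower from compound 2 to compound 3 (within the scatter). Compound 3 therefore holds the lowest of the three numbers, within the scatter of compound 2 and clearly under compound 1.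

Compound 4, `CCC(C)OC(=O)C1=C(C)NC(=O)NC1c1ccsc1`, not yet measured, carries sec-butoxy in place of isopropylsulfanyl on a carbonyl carbon. Among the measured compounds shown here, no measured step compares an oxygen-linked group with a sulfur-linked one here, so the nearest guides are the modest drops seen in a number 12 percentage points lower from compound 1 to compound 2 (beyond the scatter) and a number 13 percentage points lower from compound 1 to compound 3 (beyond the scatter), which show this position moving the read-out only by a modest amount. For compound 4 the step of a number 4 percentage points higher from compound 3 to compound 4 (within the scatter) is expected to stay small, most likely within the scatter. Compound 4 is thus estimated at 5%, with a range from 0% to 18%.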

Compound 4, a percentage reported as inhibition, at one concentration (the size of the read-out at that concentration, not a potency): 7%
Estimate against measurement, compound 4: 2 percentage points below; measured number inside the range.
By their numbers in this assay, from the lowest: compounds 3, 2, 4 and 1 (each within the scatter of the next, the first and the last beyond it).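

Among the compounds shown here, compound 4 brings the first oxygen-linked group to this carbonyl carbon, and in this assay sec-butoxy is not separated from either sulfur-linked group: the steps are a number 6 percentage points higher from compound 3 to compound 4 (within the scatter) and a number 5 percentage points higher from compound 2 to compound 4 (within the scatter). Against isobutyl the step is a number 7 percentage points lower from compound 1 to compound 4 (within the scatter), whereas both sulfanyl compounds stood beyond the scatter of compound 1, so compound 4 cannot be told apart from any of the three. Nothing available explains these numbers.

The step from isopropylsulfanyl to sec-butoxy changes both the linking atom and the chain, so the two changes cannot be separated here. Also open, going by these compounds, is what a nitrogen-linked group such as dimethylamino, or a longer chain such as n-hexyloxy, would give on this carbonyl carbon.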